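The source may hold more compounds than are shown below. What is called first, only, known or untested is meant among the compounds shown, and "the series" means these compounds.

Working notes on the series. Compound 1 `Cn1cc(-c2ccc(CN3CCC(O)(Cn4cnc5c(-c6ccc(CN)cc6)n(C)nc5c4=O)CC3)c(Cl)c2)cn1` gives 291 nM in an assay on isolated protein for inhibition of ubiquitin carboxyl-terminal hydrolase 7 (Homo sapiens), with stated times of 30 min and 2 h; a higher number here means a weaker inhibitor, a lower number a stronger inhibitor. Compound 2 `Cn1nc2c(=O)n(CC3(O)CCN(Cc4ccc(-c5ccc[nH]5)cc4Cl)CC3)cnc2c1-c1ccc(CN)cc1` differs from compound 1 only by 1H-pyrrol-2-yl in place of 1-methyl-1H-pyrazol-4-yl on an aromatic carbon; in this assay compound 2 gives 193 nM, and that step, a 1.5-fold lower number from compound 1 to compound 2 (0.18 log units; within the scatter), stays within the scatter. Compound 3 `Cn1nc2c(=O)n(CC3(O)CCN(Cc4ccc(-c5ccco5)cc4Cl)CC3)cnc2c1-c1ccc(CNS(C)(=O)=O)cc1` gives 65.3 nM and so holds the lowest of the three numbers; its gaps to compound 2 and to compound 1 both lie beyond the scatter. Among the compounds with values here, compound 3 differs from compound 2 in two places at once, so no single step is available for it.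

Compound 4 `Cn1nc2c(=O)n(CC3(O)CCN(Cc4ccc(-c5ccco5)cc4Cl)CC3)cnc2c1-c1ccc(CNC2CC2)cc1` is the next compound to be measured. Compared with compound 3, the change is cyclopropyl in place of methylsulfonyl on an amine nitrogen. Within the data shown here, none of the measured steps touches the substituent on this amine nitrogen: the one step on record, from compound 1 to compound 2, concerns the aromatic substituent and was within the scatter, and the two-place difference between compound 2 and compound 3 cannot be attributed to either change alone. The expectation for compound 4 therefore rests on compound 3 alone, with a wide range and no direction asserted beyond the scatter; the expected step is a 1.8-fold higher number from compound 3 to compound 4 (0.26 log units; within the scatter). Compound 4 is estimated at 120 nM, within 40 nM to 360 nM.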

Compound 4, half-maximal inhibitory concentration: 54.1 nM
Beside the measured number, compound 4's estimate is 2.2-fold (0.35 log units) above it, and the stated range covers the measured number.
By their numbers in this assay, from the lowest: compounds 4 and 3 (each within the scatter of the next); then compounds 2 and 1 (each within the scatter of the next).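

Within the data shown here, on the amine nitrogen of the (methanesulfonamido)methyl arm, the exchange of methylsulfonyl for cyclopropyl gives the first single-place reading at this position in this assay: a 1.2-fold lower number from compound 3 to compound 4 (0.08 log units; within the scatter). The substituent that leaves has two hydrogen-bond acceptors and the one that enters has none, yet the two numbers stay within the scatter of each other, so in this pair those acceptors are not needed to keep the number at this level. Nothing available accounts for this equivalence.

From the compounds shown here alone, compounds 1 and 2 carry the unsubstituted amine but differ from compounds 3 and 4 in more than one place, so those pairs cannot be read as steps and the effect of substituting this nitrogen at all remains open. Also open, going by these compounds, are whether an acetyl group, a carboxylic acid or a longer alkyl chain on this nitrogen would stay in the same range, and whether the equivalence of methylsulfonyl and cyclopropyl holds with the aromatic substituents of compounds 1 and 2.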